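The source may report more compounds than this note shows. Statements on the series, on what has been measured and on what is new or still open speak of the compounds shown alone.

Measured compounds, each reaching only a limit in a functional assay on L5178Y cells (Mus musculus) for inhibition, read by MTT assay, with a stated time of 24 h; a higher number here means a weaker inhibitor, a lower number a stronger inhibitor:

Compound 1 `Oc1ccc([C@@H]2C/C(=N\Nc3ccccc3)c3c(O)cc(O)cc3O2)cc1`: a limit, >= 11300 nM.
Compound 2 `Oc1ccc([C@@H]2C/C(=N\Nc3ccc(Br)cn3)c3c(O)cc(O)cc3O2)cc1`: a limit, >= 11300 nM.
Compound 3 `COc1ccc([C@@H]2C/C(=N\Nc3ccccc3)c3c(O)cc(OC)cc3O2)cc1`: a limit, >= 11300 nM.

All three values are limits rather than numbers, which is what the limit of >= 11300 nM in this assay, at which 3 of the 3 values shown sit, records. Compound 1 and compound 2 share one core and differ by 5-bromopyridin-2-yl in place of phenyl on an amine nitrogen; the step that the two limits leave unreadable from compound 1 to compound 2 cannot be read, since both ends are limits. Compound 3 carries a different core; the difference between the two cores is not broken down here.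

Compound 4, `COc1ccc([C@@H]2C/C(=N\Nc3ccc(Br)cn3)c3c(O)cc(OC)cc3O2)cc1`, has not yet been measured in this assay. It differs from compound 3 by 5-bromopyridin-2-yl in place of phenyl on an amine nitrogen, the same change that separates compound 1 from compound 2, made at the same place. Because compound 3 sits at the limit >= 11300 nM, and because the same change gave the unreadable step that the two limits leave unreadable from compound 1 to compound 2, compound 4 is expected to stay at or beyond the limit as well, so the expected step that the limit leaves unreadable from compound 3 to compound 4 is about flat. The estimate for compound 4 in this assay is 15000 nM, with a plausible range from 8000 nM to 40000 nM.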

Compound 4, half-maximal inhibitory concentration: 8000 nM
The estimate for compound 4 lay 1.9-fold (0.27 log units) above the measured number, and the stated range covers the measured number.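

On the core of compound 3, putting 5-bromopyridin-2-yl in place of phenyl on the amine nitrogen gives an at least 1.4-fold lower number from compound 3 to compound 4 (0.14 log units; that floor lies within the scatter) in this assay, and compound 4 gives a measured number where compound 3 reached only a limit. On these data alone, that printed floor does not by itself establish a real gain, though the true size of the step stays unknown. On the core of compound 1 the same change cannot be read, so nothing here shows that it carries from one core to the other or has the same size on both, and the comparison stays loose because most values sit at one limit: the limit of >= 11300 nM in this assay, at which 3 of the 4 values shown sit.

The change brings in a ring nitrogen and a bromine together, and the compounds shown do not separate the two. They also leave open how a plain pyridin-2-yl, a bromophenyl, or a carboxylic acid in place of the bromine would read in this assay.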